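Halogen exchange on the exocyclic double bond of compound 3

The source may report more compounds than this note shows. Statements on the series, on what has been measured and on what is new or still open speak of the compounds shown alone.

Compound 1 `CCC[C@@H](OC(C)=O)C1=C(Br)/C(=C/Br)OC1=O` gives 0.5 ug/mL in a functional assay on LNCaP cells (Homo sapiens) for cytotoxicity; on this read-out lower numbers stand for an effect already at smaller amounts and higher numbers for an effect only at larger amounts of compound.
Compound 2 `CCCCC1=C(Br)/C(=C/Br)OC1=O` gives 7.3 ug/mL in this assay.
Compound 3 `CCC[C@@H](O)C1=C(Br)/C(=C/I)OC1=O` gives < 0.1 ug/mL in this assay.

Compound 3 stands at the low end of the three values; its result is a limit of the assay and not a number, as the limit of < 0.1 ug/mL in this assay, at which 1 of the 3 values shown sits, records. Compound 4 `CCC[C@@H](O)C1=C(Br)/C(=C/Br)OC1=O` has not yet been measured in this assay. It differs from compound 3 in one place: bromo in place of iodo on a double-bonded chain carbon bound to a double-bonded ring carbon.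

Going by the values given here, only one step between measured compounds exists here, a 15-fold higher number from compound 1 to compound 2 (1.16 log units; beyond the scatter), and it concerns the acetoxy group on the saturated chain carbon, not the halogen on the double-bonded chain carbon. Among the compounds with values here, no measured step therefore bears directly on the change from compound 3 to compound 4. Compound 3 and compound 4 share the hydroxy group that compound 1 carries as acetoxy and compound 2 lacks, so both are expected to sit at the potent end of this series. For the exchange of iodo for bromo, the expected step from compound 3 to compound 4 is an at least 1.5-fold higher number from compound 3 to compound 4 (0.17 log units; that floor lies within the scatter), within the scatter. Compound 4 is estimated at 0.15 ug/mL, with a range from 0.05 ug/mL to 0.5 ug/mL.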

Compound 4, concentration for half-maximal effect: 0.2 ug/mL
Estimate against measurement, compound 4: 1.3-fold (0.12 log units) below; low and high end bracket the measured number.
By their numbers in this assay, from the lowest: compound 4; then compound 1; then compound 2. At a limit, below all of these: compound 3.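

In this assay the result for compound 3, which carries iodo, is a limit of the assay and not a number: the limit of < 0.1 ug/mL in this assay, at which 1 of the 4 values shown sits. As far as these compounds go, with bromo in its place on the double-bonded chain carbon the comparison gives an at least 2.0-fold higher number from compound 3 to compound 4 (0.30 log units; that floor lies within the scatter) and so fixes only a floor for this exchange, one that lies within the scatter, while the true size of the step stays unknown. Compound 4 does, however, supply a real number for the hydroxy compound with bromo at this place: hydroxy in place of hydrogen on the saturated chain carbon gives a 37-fold lower number from compound 2 to compound 4 (1.56 log units; beyond the scatter) and hydrogen in place of acetyl on the oxygen gives a 2.5-fold lower number from compound 1 to compound 4 (0.40 log units; beyond the scatter) as a further modest step, so among these three bromo compounds the free hydroxy goes with the lowest number.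

From the compounds shown here alone, how far compound 3 truly lies from compound 4 stays open, as does whether chloro on the double-bonded chain carbon would fall in line with bromo or with iodo. The compounds shown also leave open what an amine or a longer chain on the saturated chain carbon would do to this read-out.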